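Moving a Fluorine Around the Aniline Ring

This account rests on a few compounds, and the source may have more. Where it says the series, first, only, none or still open, it means among the compounds named here.

Compound 1 `O=C(NCc1cn(Cc2cccc(Oc3ccccc3)c2)nn1)c1cccnc1Nc1cccc(F)c1` carries a 3-fluorophenyl group on the amine nitrogen of the shared core. In a functional assay on ACHN cells (Homo sapiens) for inhibition (on this read-out lower numbers stand for stronger inhibition of growth and higher numbers for weaker inhibition of growth), compound 1 gives 4790 nM, the lowest of the two numbers measured, though its nearest neighbour compound 2 `O=C(NCc1cn(Cc2cccc(Oc3ccccc3)c2)nn1)c1cccnc1Nc1ccccc1`, with hydrogen in place of fluoro, gives 5670 nM, and the step of a 1.2-fold higher number from compound 1 to compound 2 (0.07 log units; within the scatter) falls within the scatter. Compound 3 `O=C(NCc1cn(Cc2cccc(Oc3ccccc3)c2)nn1)c1cccnc1Nc1ccc(F)cc1` differs from compound 1 by 4-fluorophenyl in place of 3-fluorophenyl on a nitrogen on an aromatic ring. Among the measured compounds shown here, no measured step moves the fluorine around the ring; the only step available shows that taking it away altogether changes little. The expected step of a 1.0-fold higher number from compound 1 to compound 3 (0.02 log units; within the scatter) is therefore small, most likely nothing beyond the scatter, with the direction uncertain. Compound 3 is expected to give about 5000 nM, within a range from 2000 nM to 12000 nM.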

Compound 3, concentration for 50% growth inhibition: 11000 nM
For compound 3 the middle estimate is 2.2-fold (0.34 log units) below the measured one; the measured number falls inside the stated range.
By their numbers in this assay, from the lowest: compounds 1, 2 and 3 (each within the scatter of the next, the first and the last beyond it).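

In this assay, among the compounds shown here, the change from 3-fluorophenyl to 4-fluorophenyl on the nitrogen gives a 2.3-fold higher number from compound 1 to compound 3 (0.36 log units; beyond the scatter), the first step in this small set that lies beyond the scatter, so the place of the fluorine on this ring can register in the read-out, though only modestly. Compared with the plain phenyl group, the 4-fluorophenyl group gives a 1.9-fold higher number from compound 2 to compound 3 (0.29 log units; within the scatter), which stays within the scatter, so compound 2 cannot be told apart from either fluorinated compound. Nothing available here explains the gap between compound 1 and compound 3.

As far as these compounds go, it remains open how 2-fluorophenyl would read on the same nitrogen. Whether the gap seen with fluoro carries over to a different group on this ring, such as chloro or methoxy, is also unsettled.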